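This account rests on a few compounds, and the source may have more. Where it says the series, first, only, none or still open, it means among the compounds named here.

In a functional assay on SiHa cells (Homo sapiens) for antiproliferative activity, read by CCK-8 assay, with a stated time of 72 h (on this read-out higher numbers stand for weaker inhibition and lower numbers for stronger inhibition), compound 1 (`COc1ccc(-c2cncnc2-c2cc(OC)c(OC)c(OC)c2)cc1`) gives 2850 nM, while compound 2 (`COc1cc(-c2ncncc2-c2ccc(OCC(F)(F)F)cc2)cc(OC)c1OC`) gives 33300 nM. Compound 2 therefore holds the higher of the two numbers, which means the weaker inhibition. Compound 3 (`COc1cc(-c2ncncc2-c2ccc(OC(C)C)cc2)cc(OC)c1OC`) has isopropyl in place of 2,2,2-trifluoroethyl on an oxygen on an aromatic ring. Going by the values given here, only one measured step bears on this change, and it is large: a 12-fold higher number from compound 1 to compound 2 (1.07 log units; beyond the scatter), with trifluoromethyl in place of hydrogen on a saturated chain carbon bound to an oxygen on an aromatic ring. Compound 3 also loses the 2,2,2-trifluoroethyl group, but isopropyl is not the group carried by compound 1, and a single pair establishes no pattern. Among the compounds with values here, with that one step as the only guide, a move to a lower number in this assay is expected, beyond the scatter but smaller than the step already seen. The estimate for compound 3 is 7000 nM, with an expected range from 2000 nM to 25000 nM. The expected change is a 4.8-fold lower number from compound 2 to compound 3 (0.68 log units; beyond the scatter).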

Compound 3, half-maximal inhibitory concentration: 9970 nM
Compound 3: middle estimate off by 1.4-fold (0.15 log units), on the low side, and the stated range covers the measured number.
By their numbers in this assay, from the lowest: compound 1; then compound 3; then compound 2.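

In this assay, isopropyl in place of 2,2,2-trifluoroethyl on this oxygen gives a 3.3-fold lower number from compound 2 to compound 3 (0.52 log units; beyond the scatter) and thus recovers only part of the large loss seen with the trifluoroethyl group, while isopropyl in place of methyl gives a 3.5-fold higher number from compound 1 to compound 3 (0.54 log units; beyond the scatter) as a separate, modest rise. The three groups on this oxygen therefore form an order beyond the scatter, with methyl at the lowest number, isopropyl in the middle and 2,2,2-trifluoroethyl at the highest, so this position distinguishes among small alkyl groups and a group without fluorine does not match methyl here. The single earlier step could not show this intermediate level, and nothing shown offers a measured explanation for the order.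

The compounds shown leave open how a straight propyl chain, a longer butyl chain or a cyclopropylmethyl group would sit in this order, and whether a monofluoroethyl group would fall nearer to the isopropyl or the trifluoroethyl compound. They also leave open whether a free hydroxyl or an aminoethyl chain on this oxygen would bring the number lower than that of the methyl compound.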